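This account rests on a few compounds, and the source may have more. Where it says the series, first, only, none or still open, it means among the compounds named here.

The shared core of compound 1 `ClCc1ccccc1Cn1cnc2c(Cl)nc(Cl)nc21` appears in three measured compounds. In a functional assay on NCI-H23 cells (Homo sapiens) for cytotoxicity, read by sulforhodamine B assay, with a stated time of 48 h (a higher number here means that more compound is tolerated, a lower number that less compound is tolerated), compound 1 gives 6310 nM. Compound 2 `Nc1nc(Cl)c2ncn(Cc3ccc(CCl)cc3)c2n1` gives 77600 nM in this assay, and compound 3 `ClCc1cccc(Cn2cnc3c(Cl)ncnc32)c1` gives 8710 nM. Among these three numbers compound 1 stands lowest; the nearest is compound 3, whose number lies within the scatter of that of compound 1, and the furthest is compound 2, whose number lies beyond the scatter above it. No two of these compounds differ in a single place, so no single step can be read off from the measured set.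

Compound 4 `Nc1nc(Cl)c2ncn(Cc3ccccc3CCl)c2n1` has not yet been measured. It differs from compound 1 in one place: amino in place of chloro on an aromatic carbon. Within the data shown here, compound 2 also carries an amino group on its core, though the rest of its structure differs as well, so the values of compound 1 and compound 2 show only that the amino-bearing member sits at the higher number. On this basis compound 4 is expected to be tolerated at a higher concentration than compound 1 in this assay, with an expected step of a 4.8-fold higher number from compound 1 to compound 4 (0.68 log units; beyond the scatter), beyond the scatter. The estimate for compound 4 is 30000 nM, expected to fall between 10000 nM and 90000 nM.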

Compound 4, concentration lethal to 50% of the cells: 78900 nM
Compound 4: the middle estimate sits 2.6-fold (0.42 log units) below what was measured; the range from low to high includes it.
By their numbers in this assay, from the lowest: compounds 1 and 3 (each within the scatter of the next); then compounds 2 and 4 (each within the scatter of the next).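

With the rest of the structure held the same, the exchange of chloro for amino on the aromatic carbon between two ring nitrogen atoms gives, in this assay, a 13-fold higher number from compound 1 to compound 4 (1.10 log units; beyond the scatter). The earlier compounds shown here could tie the amino group to a higher number only loosely, since the amino-bearing member also differed elsewhere, whereas this pair ties the large step to this one change at this position. No measurement available here accounts for the size of the step, so the result records the change without explaining it.

The compounds shown leave open whether the step belongs to the amino group in particular or would also appear with another group at this position, such as a methylamino, dimethylamino, hydroxyl or methoxy group. They also leave open whether the same exchange gives a step of similar size on a different structure, as this one matched pair cannot show how far the change carries beyond compound 1 and compound 4.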